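The compounds below may be only part of what the source reports. "The series", "measured", "known", "first", "only" and "open" are said of these compounds alone.

In a functional assay on PC-3 cells (Homo sapiens) for cytotoxicity, read by sulforhodamine B assay (a lower number here means a stronger inhibitor of growth, a higher number a weaker inhibitor of growth), compound 1 `COc1cccc(OC)c1OCCNCCOc1ccccc1OCc1ccccc1` gives 76900 nM, compound 2 `COc1cccc(OC)c1OCCNCCOc1ccccc1OCc1ccc(Cl)cc1` gives 14500 nM, and compound 3 `COc1cccc(OC)c1OCCNCCOc1ccccc1OCc1cccc(C)c1` gives 32300 nM. Compound 3 thus stands second highest of the three: a 2.2-fold higher number from compound 2 to compound 3 (0.35 log units; beyond the scatter), while a 2.4-fold lower number from compound 1 to compound 3 (0.38 log units; beyond the scatter). Compound 4 `COc1cccc(OC)c1OCCNCCOc1ccccc1OCc1ccc(C)cc1` differs from compound 3 by 4-methylphenyl in place of 3-methylphenyl on a saturated chain carbon bound to an oxygen on an aromatic ring. Within the data shown here, no measured pair shows this change directly; the nearest guides are a 5.3-fold lower number from compound 1 to compound 2 (0.72 log units; beyond the scatter) and a 2.4-fold lower number from compound 1 to compound 3 (0.38 log units; beyond the scatter), both modest lowerings from the parent ring, together with a 2.2-fold higher number from compound 2 to compound 3 (0.35 log units; beyond the scatter). On this basis a modest step is expected in this assay, most likely toward a somewhat lower number, so that a 1.5-fold lower number from compound 3 to compound 4 (0.17 log units; within the scatter) is estimated. Compound 4 is therefore expected to give about 22000 nM, with a range from 10000 nM to 45000 nM.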

Compound 4, concentration for total growth inhibition: 27500 nM
Beside the measured number, compound 4's estimate is 1.3-fold (0.10 log units) below it; the measured number falls inside the stated range.
By their numbers in this assay, from the lowest: compounds 2, 4 and 3 (each within the scatter of the next, the first and the last beyond it); then compound 1.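

In this assay, 3-methylphenyl and 4-methylphenyl on a saturated chain carbon bound to an oxygen on an aromatic ring are not told apart, a 1.2-fold lower number from compound 3 to compound 4 (0.07 log units; within the scatter). Methyl and chloro on the aromatic carbon are likewise not separated in this pair, a 1.9-fold higher number from compound 2 to compound 4 (0.28 log units; within the scatter), whereas methyl in place of hydrogen there gives a step beyond the scatter, a 2.8-fold lower number from compound 1 to compound 4 (0.45 log units; beyond the scatter). No supporting measurement is available to explain these steps. On these data alone, compound 2 gives 14500 nM, and whether a methoxy group, a trifluoromethyl group or a carboxylic acid on this ring would give a still lower number stays open. So does whether these steps would carry over to a longer chain in place of the saturated chain carbon.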